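Working notes: carbonyl replacement on the ring amine

A few compounds are considered here, and "the series" means these few. Any claim that something is new, unique, unknown or untested is made for them only; others in the source may bear on it.

The series is followed in an assay on HEK293 cells for agonist activity at Toll-like receptor 8 (Homo sapiens), read by a luciferase reporter, with a stated time of 6 h; on this read-out lower numbers stand for an effect already at smaller amounts and higher numbers for an effect only at larger amounts of compound. Going by the values given here, compound 1 `CCCCNc1nc(N)nc2c1CN(C)CC2` gives 0.03 uM and stands at the lowest number of the two measured so far. Among the compounds with values here, compound 2 `CCCCNc1nc(N)nc2c1CCN(C)C2` gives 0.2 uM, a higher number than compound 1, and the two values lie beyond the usual scatter of each other; no step between them is described here beyond what the two numbers show.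

Compound 3 `CCCCNc1nc(N)nc2c1CN(C(=O)c1cc(C)on1)CC2` remains to be measured in this assay. It differs from compound 1 in one place: (5-methyl-1,2-oxazol-3-yl)carbonyl in place of methyl on an amine nitrogen in a ring. The change thus puts a (5-methyl-1,2-oxazol-3-yl)carbonyl in place of a methyl on the amine nitrogen in the ring of the six-membered non-aromatic ring, part of the fused system.

Within the data shown here, no comparable step between measured compounds is available, so the direction of the change rests on the two values alone. A step toward higher numbers of moderate size is expected in this assay, a 5.0-fold higher number from compound 1 to compound 3 (0.70 log units; beyond the scatter), with considerable uncertainty. For compound 3 the estimate is 0.15 uM, with a range from 0.03 uM to 1.5 uM.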

Compound 3, minimum effective concentration: 0.4 uM
Compound 3: middle estimate off by 2.7-fold (0.43 log units), on the low side, within the range that was stated.
By their numbers in this assay, from the lowest: compound 1; then compounds 2 and 3 (each within the scatter of the next).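

Going by these compounds alone, this gives the first reading of how the amine nitrogen in the ring responds to a change of substituent in this assay: replacing methyl with (5-methyl-1,2-oxazol-3-yl)carbonyl produces a 13-fold higher number from compound 1 to compound 3 (1.12 log units; beyond the scatter) and so counts as a large step beyond the scatter. The position is therefore sensitive to this change, yet the effect is not lost, since compound 3 still gives 0.4 uM in this read-out, so a carbonyl-linked five-membered aromatic ring can be carried here at a clear cost. No available evidence bears on why the number rises or on whether the carbonyl or the aromatic ring accounts for the step.

Still open, on these data alone, is whether a plain acetyl group, or a benzyl group without the carbonyl, on the same nitrogen would separate the contribution of the carbonyl from that of the ring. Also open, as far as these compounds go, are whether a bare ring amine carrying only hydrogen would give a lower number than compound 1, and whether the same (5-methyl-1,2-oxazol-3-yl)carbonyl on the ring nitrogen of compound 2 would produce a step of similar size.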